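A few compounds are considered here, and "the series" means these few. Any claim that something is new, unique, unknown or untested is made for them only; others in the source may bear on it.

Measured in a functional assay on OVCAR-5 cells (Homo sapiens) for inhibition, read by CCK-8 assay, with a stated time of 72 h, tested at 1 uM; on this read-out lower numbers stand for less inhibition of growth and higher numbers for more inhibition of growth at the one concentration tested:
- compound 1 `CN(C)C(=O)c1cc2cnc(Nc3ccc(NC(=O)C4(C(=O)Nc5ccc(F)cc5)CC4)cc3)nc2n1C1CCCC1`: 65.4%
- compound 2 `CN(C)C(=O)c1cc2cnc(Nc3ccc(NC(=O)C4(C(=O)Nc5ccc(O)cc5)CC4)cc3)nc2n1C1CCCC1`: 80.7%

Compound 2 stands higher of these two in this assay. The next structure is compound 3 `CN(C)C(=O)c1cc2cnc(Nc3ccc(NC(=O)C4(C(=O)Nc5ccccc5)CC4)cc3)nc2n1C1CCCC1`, and the change is hydrogen in place of hydroxy on an aromatic carbon. Within the data shown here, one measured step bears on it: a number 15.3 percentage points higher from compound 1 to compound 2 (beyond the scatter), a modest rise where hydroxy replaced fluoro on that same carbon. Among the measured compounds shown here, removing the hydroxy again is therefore expected to give a fall of similar size, though no measurement yet shows this for hydrogen. The expected change is a number 12.7 percentage points lower from compound 2 to compound 3 (beyond the scatter). Compound 3 is estimated at 68%, within a range of 52% to 82%.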

Compound 3, percent growth inhibition at one concentration: 52.1%
Estimate against measurement, compound 3: 15.9 percentage points above, and the stated range covers the measured number.
By their numbers in this assay, from the lowest: compound 3; then compound 1; then compound 2.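

Taking the hydroxy away in this assay gives a number 28.6 percentage points lower from compound 2 to compound 3 (beyond the scatter), and taking the fluoro away gives a number 13.3 percentage points lower from compound 1 to compound 3 (beyond the scatter). The plain phenyl therefore ranks below both substituted rings, so either group on this carbon, para to a large group, goes with more growth inhibition than hydrogen does. Nothing available explains this order.

From the compounds shown here alone, whether a methoxy group, an amine or a chlorine on this carbon would match hydroxy stays open. So does whether hydroxy or fluoro would give the same order on another carbon of this ring.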